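This account rests on a few compounds, and the source may have more. Where it says the series, first, only, none or still open, it means among the compounds named here.

Measured in a functional assay on MCF7 cells (Homo sapiens) for antiproliferative activity, read by sulforhodamine B assay, with a stated time of 72 h; on this read-out lower numbers stand for stronger inhibition and higher numbers for weaker inhibition:
- Compound 1 `COc1c(OC(C)C)cc2occ(-c3csc4ccccc34)c(=O)c2c1O`: > 10000 nM (a limit, not a number)
- Compound 2 `CCOc1cc2occ(-c3csc4ccccc34)c(=O)c2c(OCC)c1OC`: 3100 nM
- Compound 3 `COc1cc2occ(-c3csc4ccccc34)c(=O)c2c(OC)c1OC`: 740 nM

Of the two actual numbers, compound 3 holds the lower, and its gap to compound 2 lies beyond the scatter. Compound 4 `COc1cc2occ(-c3csc4ccccc34)c(=O)c2c(OC)c1O` differs from compound 3 in one place: hydrogen in place of methyl on an oxygen on an aromatic ring, a change from methoxy to hydroxy. Going by the values given here, no measured pair shows this change alone. Among the compounds with values here, the only measured compound with a hydroxy, compound 1, stands at the limit of > 10000 nM, though it differs in other places too. A moderate weakening beyond the scatter is therefore expected in this assay. The expected size is a 2.7-fold higher number from compound 3 to compound 4 (0.43 log units; beyond the scatter). For compound 4, the estimate is 2000 nM, with an expected range of 500 nM to 9000 nM.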

Compound 4, half-maximal inhibitory concentration: > 10000 nM
Compound 4 gave a limit, no number; the forecaster's own chance of this, stated with the estimate: 15%; middle value at least 5.0-fold (0.69 log units) from the limit.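

In this assay, going by these compounds alone, the change from methoxy to hydroxy now stands alone for the first time, and it gives an at least 13-fold higher number from compound 3 to compound 4 (1.13 log units; beyond the scatter); the earlier hydroxy compound, compound 1, differed in other places too. This one change on an oxygen on an aromatic ring is therefore enough to take the compound to the limit. Compound 4 gives > 10000 nM, which is a limit and not a number, so the full size of the step is unknown, and this limit recurs: the limit of > 10000 nM in this assay, at which 2 of the 4 values shown sit.

The compounds shown leave open how far compound 4 truly lies from compound 3. They also leave open how an amine or a butoxy chain in this place would read in this assay.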